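The compounds below may be only part of what the source reports. "The series", "measured", "known", "first", "only" and "open" are said of these compounds alone.

Measured compounds:
compound 1 `COc1cc(C(=O)Nc2nn[nH]n2)nc(-c2ccccc2)c1` — 97%
compound 2 `COc1cc(C(=O)Nc2nn[nH]n2)nc(-c2ccc(N(C)C)cc2)c1` — 100%

Both values come from a functional assay on the whole organism with Rattus norvegicus as the target, at a dose of 3 mg/kg by the oral route; a higher number here means a stronger effect of the compound at the dose given, a lower number a weaker effect. Among the compounds with values here, compound 1 holds the lower of the two numbers, and its only neighbour is compound 2, reached by a number 3 percentage points higher from compound 1 to compound 2 (within the scatter). Compound 3 `CCCCc1cc(C(=O)Nc2nn[nH]n2)nc(-c2ccccc2)c1` has not been measured. It differs from compound 1 in one place: butyl in place of methoxy on an aromatic carbon. Within the data shown here, no measured step touches this position or exchanges a methoxy for a chain, so the one known step, from compound 1 to compound 2, gives no direct guide. Given that compound 1 reaches 97%, the estimate for compound 3 is 88%, within 60% to 100%, which is expected to correspond to a number 9 percentage points lower from compound 1 to compound 3 (within the scatter).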

Compound 3, a percentage reported as inhibition, in the whole organism at one dose (the size of the read-out at that dose, not a potency): 71%
For compound 3 the middle estimate is 17 percentage points above the measured one, within the range that was stated.
By their numbers in this assay, from the lowest: compound 3; then compounds 1 and 2 (each within the scatter of the next).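

In this assay, within the data shown here, the position opposite the ring nitrogen is not indifferent to its group: butyl in place of methoxy gives a number 26 percentage points lower from compound 1 to compound 3 (beyond the scatter) and this is the first step here that lies beyond the scatter. The change swaps the oxygen-bearing methoxy for an all-carbon chain with more heavy atoms, and this single step cannot separate those two differences. Nothing at hand bears on the reason for the loss.

Still open, on these data alone, is how an ethoxy group, a propyl chain or an amine would compare at this position. Also open, as far as these compounds go, is whether the oxygen or the chain length is what counts.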